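This account rests on a few compounds, and the source may have more. Where it says the series, first, only, none or still open, it means among the compounds named here.

For the measured compounds named here, compound 2 `COc1nc2ccc(Br)cc2cc1C(c1ccccc1)n1cc(CCCO)nn1` is one of two compounds so far measured in an ADME assay on SK-OV-3 cells (Homo sapiens) for cytotoxicity, read by sulforhodamine B assay, with a stated time of 48 h, tested at 10 uM; a lower number here means less inhibition, a higher number more inhibition at the concentration tested (going by the name of the read-out); compound 2 gives 13.8%, while compound 1 `COc1nc2ccc(Br)cc2cc1C(c1ccccc1)n1cc(-c2ccc(Br)cc2)nn1` gives 13.4%, the two numbers lying within the scatter of each other. Compound 3 `CCCCCc1cn(C(c2ccccc2)c2cc3cc(Br)ccc3nc2OC)nn1` differs from compound 2 by ethyl in place of hydroxy on a saturated chain carbon, three bonds along the chain from an aromatic carbon. Going by the values given here, the only measured step, a number 0.4 percentage points higher from compound 1 to compound 2 (within the scatter), swapped 4-bromophenyl for 3-hydroxypropyl without moving the number beyond the scatter, and no measured step touches the hydroxy itself. The expected step of a number 0.2 percentage points higher from compound 2 to compound 3 (within the scatter) is therefore none beyond the scatter. Compound 3 is estimated at 14%, between 3% and 30%.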

Compound 3, a percentage reported as inhibition, at one concentration (the size of the read-out at that concentration, not a potency): 10.5%
Compound 3: middle estimate off by 3.5 percentage points, on the high side; measured number inside the range.
By their numbers in this assay, from the lowest: compounds 3, 1 and 2 (each within the scatter of the next).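

For the compounds shown here, the hydroxy itself is now changed for the first time: in this assay there is a number 3.3 percentage points lower from compound 2 to compound 3 (within the scatter), so exchanging 3-hydroxypropyl for pentyl leaves the read-out within the scatter. The step of a number 2.9 percentage points lower from compound 1 to compound 3 (within the scatter), with pentyl in place of 4-bromophenyl, also stays within the scatter, so all three groups on this aromatic carbon give indistinguishable numbers. Nothing available bears on why these numbers stay together. Going by these compounds, whether an amine or a carboxylic acid in place of the hydroxy would move the number beyond the scatter remains open.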